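Aryl ether series: a trichlorophenyl variant of compound 2

A few compounds are considered here, and "the series" means these few. Any claim that something is new, unique, unknown or untested is made for them only; others in the source may bear on it.

Two compounds of this series have numbers in a functional assay on A549 cells (Homo sapiens) for antiproliferative activity, read by MTT assay, with a stated time of 72 h; a higher number here means a weaker inhibitor, a lower number a stronger inhibitor. Compound 1 `NC1=NC2(CCSCC2)N(OCCCOc2ccc(Cl)c(Cl)c2)C(N)=N1` gives 1 nM in this assay. Compound 2 `NC1=NC2(CCOCC2)N(OCCCOc2ccccc2Cl)C(N)=N1` gives 2700 nM in this assay, the highest of the two numbers shown; its gap to compound 1 is beyond the scatter, but the two compounds differ in more than one place, so no single-change step between measured compounds is available and nothing can be attributed to the aryl ring alone.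

Compound 3 `NC1=NC2(CCOCC2)N(OCCCOc2cc(Cl)c(Cl)cc2Cl)C(N)=N1` is not yet measured. It differs from compound 2 by 2,4,5-trichlorophenyl in place of 2-chlorophenyl on an oxygen on a saturated carbon, keeping the core of compound 2 unchanged. With only the wide spread between compound 1 and compound 2 as guidance, the expectation rests on a weak basis. The step from compound 2 to compound 3 is expected to be an 18-fold lower number from compound 2 to compound 3 (1.26 log units; beyond the scatter), downward and beyond the scatter. Compound 3 is accordingly estimated at 150 nM in this assay, within a range of 10 nM to 2000 nM.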

Compound 3, half-maximal inhibitory concentration: 680 nM
Compound 3: middle estimate off by 4.5-fold (0.66 log units), on the low side, within the range that was stated.
By their numbers in this assay, from the lowest: compound 1; then compound 3; then compound 2.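

In this assay, the aryl end of the series now has its first single-change reading: 2,4,5-trichlorophenyl in place of 2-chlorophenyl, on an oxygen on a saturated carbon, gives a 4.0-fold lower number from compound 2 to compound 3 (0.60 log units; beyond the scatter), with the core of compound 2 unchanged. This position therefore responds to added chlorine on the aryl ring, although the step is modest and rests on one pair. Nothing at hand speaks to the reason for this step.

From the compounds shown here alone, compound 1 and compound 2 differ in more than one place, so how their gap divides between the aryl ring and the core remains open. Also open, going by these compounds, is whether a methoxy group or a nitrile on the aryl ring, or a longer chain carrying it, would shift the number in the same direction.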